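The source may report more compounds than this note shows. Statements on the series, on what has been measured and on what is new or still open speak of the compounds shown alone.

Compound 1 `OCCCN1CCCC[C@H]1c1nc(-c2ccc3ccccc3c2)no1` and compound 2 `OCCCCN1CCCC[C@H]1c1nc(-c2ccc3ccccc3c2)no1` share a core and differ by hydroxymethyl in place of hydroxy on a saturated chain carbon, three bonds along the chain from an amine nitrogen in a ring. In an assay on HepG2 cells for antagonist activity at Bile acid receptor (Homo sapiens), read by a luciferase reporter (on this read-out higher numbers stand for weaker inhibition and lower numbers for stronger inhibition), compound 1 gives 27000 nM, and compound 2 gives 7000 nM; this change makes a 3.9-fold lower number from compound 1 to compound 2 (0.59 log units; beyond the scatter). Compound 3 `OCCCN1CCC[C@H]1c1nc(-c2ccc3ccccc3c2)no1` carries a different core, and the difference between the two cores is not broken down here; in this assay compound 3 gives 20500 nM, which sits within the scatter of compound 1 and beyond it only against compound 2. Compound 4 `OCCCCN1CCC[C@H]1c1nc(-c2ccc3ccccc3c2)no1` is built from compound 3 by the same change, (hydroxymethyl in place of hydroxy on a saturated chain carbon, three bonds along the chain from an amine nitrogen in a ring), that turned compound 1 into compound 2. Among the compounds with values here, since the change occurs only once among the measured compounds, the expectation for compound 4 rests on a single step, the one from compound 1 to compound 2, applied to the value of compound 3. On that basis the step from compound 3 to compound 4 is expected to be about a 3.4-fold lower number from compound 3 to compound 4 (0.53 log units; beyond the scatter). Compound 4 is therefore estimated at 6000 nM in this assay, with a likely range from 2500 nM to 15000 nM.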

Compound 4, half-maximal inhibitory concentration: 33800 nM
The estimate for compound 4 lay 5.6-fold (0.75 log units) below the measured number, and the stated range ends below it.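

In this assay the change from hydroxy to hydroxymethyl gives a 1.6-fold higher number from compound 3 to compound 4 (0.22 log units; within the scatter) and so, on the core of compound 3, leaves a step that cannot be told from the scatter. Set beside the step on the core of compound 1, the same change does not carry over in size: the same change on two cores in this assay, a 3.9-fold lower number (0.59 log units; beyond the scatter) from compound 1 to compound 2 and a 1.6-fold higher number (0.22 log units; within the scatter) from compound 3 to compound 4, 6.4-fold (0.80 log units) apart, beyond the scatter of two such steps. This shows that, for these two cores, a gain seen on one core could not be transferred to the other, but with a single pair on each core it does not show why the steps part, nor does it give a rule for any further core.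

The compounds shown stop at 4-hydroxybutyl, so they leave open how the two cores would respond to a longer chain such as 5-hydroxypentyl. They also leave open whether a carboxylic acid or an amine in place of the hydroxy would behave alike on both cores.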